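Fluorine placement on the aryl of the shared core

The source may hold more compounds than are shown below. What is called first, only, known or untested is meant among the compounds shown, and "the series" means these compounds.

Compound 1 `COc1cc(NC(C)CCCNC(=O)Nc2ccc(F)cc2)c2ncccc2c1` is the reference point of this small set. For the measured compounds named here, in a functional assay on HeLa cells (Homo sapiens) for inhibition, read by MTT assay, with a stated time of 72 h (on this read-out higher numbers stand for weaker inhibition and lower numbers for stronger inhibition), compound 1 gives 20000 nM, the lowest of the three numbers so far. Compound 2 `COc1cc(NC(C)CCCNC(=O)Nc2ccc(O)cc2)c2ncccc2c1` gives 70000 nM in this assay, and compound 3 `COc1cc(NC(C)CCCNC(=O)NNC(=O)Nc2cccc(Cl)c2)c2ncccc2c1` gives 44000 nM in this assay. The steps away from compound 1 are a 3.5-fold higher number from compound 1 to compound 2 (0.54 log units; beyond the scatter) and a 2.2-fold higher number from compound 1 to compound 3 (0.34 log units; beyond the scatter); between the other two, a 1.6-fold lower number from compound 2 to compound 3 (0.20 log units; within the scatter).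

Compound 4 `COc1cc(NC(C)CCCNC(=O)Nc2cccc(F)c2)c2ncccc2c1` is not yet measured. Its difference from compound 1 is 3-fluorophenyl in place of 4-fluorophenyl on an amide-type nitrogen. Going by the values given here, no measured pair isolates this move of a single fluorine on the aryl. The nearest guides are a 3.5-fold higher number from compound 1 to compound 2 (0.54 log units; beyond the scatter), where a different group on the aromatic carbon gave a higher number, and a 2.2-fold higher number from compound 1 to compound 3 (0.34 log units; beyond the scatter), where the 4-fluorophenyl was replaced by ((3-chlorophenyl)carbamoyl)amino, again with a higher number. Both of those are larger changes than the one here, which keeps every atom. A step no bigger than the scatter, or at most a slight weakening, is therefore expected.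

Compound 4 is expected to give 25000 nM in this assay. The expected range for compound 4 runs from 10000 nM to 60000 nM. That estimate means a 1.3-fold higher number from compound 1 to compound 4 (0.10 log units; within the scatter) is expected, within the scatter.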

Compound 4, half-maximal inhibitory concentration: 18000 nM
The estimate for compound 4 lay 1.4-fold (0.14 log units) above the measured number; the measured number falls inside the stated range.
By their numbers in this assay, from the lowest: compounds 4 and 1 (each within the scatter of the next); then compounds 3 and 2 (each within the scatter of the next).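

In this assay the fluorine move from 4-fluorophenyl to 3-fluorophenyl on the amide-type nitrogen now has its own measured pair, and the step is a 1.1-fold lower number from compound 1 to compound 4 (0.05 log units; within the scatter) with no order to be drawn between the two compounds. The gaps to the other two compounds hold for the new fluoro compound as well, with a 2.4-fold lower number from compound 3 to compound 4 (0.39 log units; beyond the scatter) and a 3.9-fold lower number from compound 2 to compound 4 (0.59 log units; beyond the scatter) both printed as beyond the scatter, so for this one pair the place of the fluorine does not alter where the compound stands against the ((3-chlorophenyl)carbamoyl)amino and 4-hydroxyphenyl compounds. No measurement available here bears on why the two fluorine placements read alike.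

On these data alone, this reading rests on a single pair and on fluorine alone, so it remains open whether a chlorine, a methoxy group or a hydroxy group carried in the 3-fluorophenyl arrangement would read like compound 4 or like compound 2. Also open, as far as these compounds go, is how an amine or a carboxylic acid on this aryl would read, and whether a longer chain between the aryl and the amide-type nitrogen would leave the number where compound 1 and compound 4 sit.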